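Extending the chain: compound 2 to compound 3

This account rests on a few compounds, and the source may have more. Where it says the series, first, only, none or still open, it means among the compounds named here.

In a functional assay on L1210 cells (Mus musculus) for inhibition, with a stated time of 48 h (on this read-out lower numbers stand for stronger inhibition and higher numbers for weaker inhibition), compound 1 `CCNCCCNCCCN` gives > 100000 nM, which is a limit of the assay. Among the measured compounds shown here, compound 2 `CCNCCCCNCCCNCC` gives 100000 nM, the only actual number so far. Compound 3 `CCNCCCCCNCCCCNCC` carries 2-(ethylamino)ethyl in place of ethylamino on a saturated chain carbon, three bonds along the chain from an amine nitrogen. For the measured compounds named here, the sole measured step bearing on this is a number no higher from compound 1 to compound 2 (the limit leaves the size open), and its size remains open. The estimated step, a 1.7-fold lower number from compound 2 to compound 3 (0.22 log units; within the scatter), is expected to stay small, leaning slightly toward lower numbers. For compound 3 the expected value is 60000 nM, with an estimated range of 15000 nM to 150000 nM.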

Compound 3, half-maximal inhibitory concentration: 4500 nM
The estimate for compound 3 lay 13-fold (1.12 log units) above the measured number; the measured number lies below the stated range.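

In this assay, among the compounds shown here, 2-(ethylamino)ethyl in place of ethylamino on a saturated chain carbon, three bonds along the chain from an amine nitrogen, gives a 22-fold lower number from compound 2 to compound 3 (1.35 log units; beyond the scatter), the first step of readable size. The earlier step from compound 1 to compound 2 cannot be read, as it starts from a limit: the limit of > 100000 nM in this assay, at which 1 of the 3 values shown sits. Both groups carry the same donor and acceptor counts, so the large drop comes with a change in chain, 5 heavy atoms against 3, and no change in those counts. As far as these compounds go, whether a longer chain at this place lowers the number further stays open. So does whether an ether oxygen could stand in for the amine nitrogen of the entering group.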